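Replacing Pentyl with 4-Methoxyphenyl on the Aromatic Nitrogen

A few compounds are considered here, and "the series" means these few. Any claim that something is new, unique, unknown or untested is made for them only; others in the source may bear on it.

The account starts from compound 1 (`CCCCCn1ccnc1-c1cc(OC)c(OC)c(OC)c1`), a compound with a pentyl chain on an aromatic nitrogen. In an ADME assay on HUVEC cells (Homo sapiens) for cytotoxicity, read by MTT assay, with a stated time of 72 h (a lower number here means a stronger inhibitor, a higher number a weaker inhibitor), compound 1 is recorded as "not determined" (no result reported), so it gives no number from which to measure. The only measured result in the pair comes from compound 2 (`COc1cc(-c2nccn2-c2ccc3cc[nH]c3c2)cc(OC)c1OC`), which reads 40000 nM.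

Still unmeasured is compound 3 (`COc1ccc(-n2ccnc2-c2cc(OC)c(OC)c(OC)c2)cc1`). The structural change is 4-methoxyphenyl in place of pentyl on an aromatic nitrogen, with 4-methoxyphenyl in place of pentyl on an aromatic nitrogen.

Among the compounds with values here, no step between measured compounds exists in this assay, and the size and direction of any step away from compound 1 cannot be stated. The expectation therefore leans on a single neighbour, and a single neighbour is thin support. Like compound 3, compound 2 carries an aromatic group on that nitrogen, and it reads 40000 nM. Compound 3 is expected to fall in the same broad region, perhaps somewhat lower, with a wide margin of uncertainty in either direction.

The estimated value for compound 3 is 20000 nM, within an expected range of 2000 nM to 80000 nM.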

Compound 3, half-maximal inhibitory concentration: > 50000 nM
Compound 3: a limit, no number; the forecaster's own chance of this, stated with the estimate: 25%; middle value at least 2.5-fold (0.39 log units) away from the limit.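

In this assay compound 3 reads > 50000 nM, which is a limit and not a number. With no single number for compound 1 either, no step can be read between compound 1 and compound 3. The compounds shown leave open how far, and in which direction, 4-methoxyphenyl in place of pentyl on the aromatic nitrogen moves the value in this assay.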